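The compounds below may be only part of what the source reports. "The series", "measured", "known", "first", "only" and "open" are said of these compounds alone.

Notes on the series. Compound 1 `CC(C)(C)Cc1c(-c2ccncc2)sc(N)c1C(=O)c1ccc(Cl)cc1` carries the shared core with a pyridin-4-yl on the ring carbon next to the ring sulfur; in an assay on CHO cells for displacement of a labelled ligand from adenosine receptor A3 (Homo sapiens), read by scintillation counting, tested at 10 uM (a higher number here means more inhibition at the concentration tested (going by the name of the read-out), a lower number less inhibition), compound 1 gives 6%. Compound 2 `CC(C)(C)Cc1c(Br)sc(N)c1C(=O)c1ccc(Cl)c(Cl)c1` and compound 3 `CC(C)(C)Cc1c(Br)sc(N)c1C(=O)c1cccc(C(F)(F)F)c1` carry a bromine at that position and differently substituted benzoyl groups; in this assay compound 2 gives 1%, and compound 3 gives 4%. Compound 1 shows the largest number of the three, but its gaps to compound 3 and to compound 2 both lie within the scatter, so no order among the three is supported and all three numbers are level and low at the concentration tested.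

Compound 4 `CC(C)(C)Cc1c(-c2cccs2)sc(N)c1C(=O)c1ccc(Cl)cc1` differs from compound 1 in one place: thiophen-2-yl in place of pyridin-4-yl on an aromatic carbon. Within the data shown here, no measured pair isolates this change, so there is no step to rest on. With compound 1 at 6%, the step from compound 1 to compound 4 in this assay is expected to be none beyond the scatter, that is a number 2 percentage points higher from compound 1 to compound 4 (within the scatter). Compound 4 is therefore estimated at 8%, between 0% and 25%.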

Compound 4, a percentage reported as inhibition, at one concentration (the size of the read-out at that concentration, not a potency): 1%
Beside the measured number, compound 4's estimate is 7 percentage points above it; measured number inside the range.
By their numbers in this assay, from the lowest: compounds 2, 4, 3 and 1 (each within the scatter of the next).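

Among these compounds, putting thiophen-2-yl in place of pyridin-4-yl on the aromatic carbon next to the ring sulfur gives a number 5 percentage points lower from compound 1 to compound 4 (within the scatter) in this assay and so provides the first direct comparison at this position. A five-membered aromatic ring with a sulfur and a six-membered aromatic ring with a nitrogen therefore cannot be told apart in this read-out, and both compounds remain low at the concentration tested. Nothing available bears on the reason for these low numbers.

On these data alone, whether an aminomethyl group, a carboxylic acid or a longer alkyl chain on this carbon would give a number beyond the scatter remains open. Also open, as far as these compounds go, is whether replacing the neopentyl group or the amino group with another group would change the read-out at all.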